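Trimming the Chain on the Aniline Nitrogen

A few compounds are considered here, and "the series" means these few. Any claim that something is new, unique, unknown or untested is made for them only; others in the source may bear on it.

Compound 2, whose structure is `CC(C)N(C[C@H]1COC(N)=N1)c1ccccc1`, was tested in a functional assay on HEK293 cells for agonist activity at trace amine-associated receptor 1 (Homo sapiens), read by cAMP accumulation, with a stated time of 30 min (on this read-out higher numbers stand for an effect only at larger amounts of compound and lower numbers for an effect already at smaller amounts), where compound 2 gives 140 nM. Among the two compounds measured so far this is the lowest number, but the only comparison available is compound 1, with the structure `CCN(C[C@@H]1COC(N)=N1)c1ccccc1`, which in this assay gives 230 nM. The gap between these two values lies within the usual scatter of repeated measurements, so the two compounds cannot be ranked against each other on this evidence.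

Compound 3, with the structure `CCN(C[C@H]1COC(N)=N1)c1ccccc1`, has not yet been measured. It differs from compound 2 in one place: hydrogen in place of methyl on a saturated chain carbon bound to a nitrogen on an aromatic ring and a saturated chain carbon. Among the measured compounds shown here, no pair of measured compounds isolates this particular change, so there is no measured step to lean on. With so small an alteration and no guidance from the measured pairs, the expectation is a modest move at most, in no firm direction, probably not beyond the scatter. Expected, then, is a 1.4-fold higher number from compound 2 to compound 3 (0.15 log units; within the scatter). Compound 3 is accordingly estimated to give 200 nM in this assay, with a likely range from 80 nM to 500 nM.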

Compound 3, half-maximal effective concentration: 59 nM
For compound 3 the middle estimate is 3.4-fold (0.53 log units) above the measured one, outside the stated range (below it).
By their numbers in this assay, from the lowest: compound 3; then compounds 2 and 1 (each within the scatter of the next).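

In this assay, the change from isopropyl to ethyl gives a 2.4-fold lower number from compound 2 to compound 3 (0.38 log units; beyond the scatter) and so moves the number by more than the usual scatter. Among the compounds shown here, this is the first sign that the size of the chain on the nitrogen counts at this position, since the earlier comparison could not separate compounds 1 and 2. With the ethyl group kept in place, the stereocentre at a saturated ring carbon also counts, as drawing it S rather than R gives a 3.9-fold lower number from compound 1 to compound 3 (0.59 log units; beyond the scatter), and this step can be put down to configuration alone: the fact that compounds 1 and 3 differ only in the configuration as drawn

The compounds shown leave open how the number responds to other groups on this nitrogen, whether a smaller methyl, a longer propyl chain or a cyclopropyl ring, so the two chains compared here mark no optimum. They also leave open whether the step from isopropyl to ethyl keeps its size when the stereocentre is drawn R, and whether the preference for S holds with groups other than ethyl on the nitrogen.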